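The source may hold more compounds than are shown below. What is called first, only, known or untested is meant among the compounds shown, and "the series" means these compounds.

In a functional assay on B16-F10 cells (Mus musculus) for inhibition, read by MTT assay, with a stated time of 72 h (on this read-out higher numbers stand for weaker inhibition and lower numbers for stronger inhibition), only two of the first three compounds carry a number. Compound 1 `CC1(C)CC(NC(=O)Nc2ccccc2Cl)c2cc(F)ccc2O1` has the entry "not determined" (no result reported) here. For the measured compounds named here, compound 2 `CC1(C)CC(NC(=O)Nc2ccccc2Cl)c2cc(Cl)ccc2O1` reads 20000 nM and compound 3 `CC1(C)CC(NC(=O)Nc2ccccc2Cl)c2cc(Br)ccc2O1` reads 22000 nM so compound 2 stands level with its only measured neighbour. The step of a 1.1-fold higher number from compound 2 to compound 3 (0.04 log units; within the scatter) comes from bromo in place of chloro on an aromatic carbon, and it stays within the scatter.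

Compound 4 `CC1(C)CC(NC(=O)Nc2ccc(Cl)cc2)c2cc(Cl)ccc2O1` has yet to be measured. It differs from compound 2 as follows: 4-chlorophenyl in place of 2-chlorophenyl on an amide-type nitrogen with 4-chlorophenyl in place of 2-chlorophenyl on an amide-type nitrogen. Going by the values given here, the one measured step lies on an aromatic carbon and not at this place, so it bears only loosely on the change. Among the compounds with values here, no measured step shows what this change does, so no shift beyond the scatter is expected and the direction stays open. The expectation is anchored on compound 2 at 20000 nM in this series. The expected change is a 1.1-fold lower number from compound 2 to compound 4 (0.05 log units; within the scatter) as an estimate only. Compound 4 is estimated at 18000 nM with an expected range from 7000 nM to 45000 nM in this assay when it is measured.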

Compound 4, half-maximal inhibitory concentration: 32000 nM
Compound 4: middle estimate off by 1.8-fold (0.25 log units), on the low side; low and high end bracket the measured number.
By their numbers in this assay, from the lowest: compounds 2, 3 and 4 (each within the scatter of the next).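

In this assay, for the compounds shown here, the earlier compounds spoke only to the halogen on an aromatic carbon of the shared core, whereas compound 4 gives the first reading at the aryl group on the amide-type nitrogen. There, a 1.6-fold higher number from compound 2 to compound 4 (0.20 log units; within the scatter) goes with 4-chlorophenyl in place of 2-chlorophenyl, so two compounds with the same atoms joined differently cannot be told apart on this read-out. Nothing shown offers an explanation for this result.

The compounds shown leave open whether a different group on the amide-type nitrogen, such as an unsubstituted phenyl, a methoxyphenyl or a longer alkyl chain, would shift the number beyond the scatter. As far as these compounds go, it also remains open whether chloro on that aryl ring could be replaced by nitrile or trifluoromethyl without such a shift.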